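Amide series on a shared core: from compound 3 to compound 4

The compounds below may be only part of what the source reports. "The series", "measured", "known", "first", "only" and "open" are said of these compounds alone.

Among the compounds with values here, the three measured members share one core and differ only at the carbonyl substituent. Compound 1 `CCOC(=O)c1c(O)c2cccnc2n(-c2ccccc2)c1=O` gives 15.5% in a functional assay on the whole organism for inhibition, with Rattus norvegicus as the target, read by cytopathic effect and paw edema, at a dose of 100 mg/kg by the oral route; a lower number here means less inhibition, a higher number more inhibition at the dose given (going by the name of the read-out). Compound 2 `O=C(Nc1ccccn1)c1c(O)c2cccnc2n(-c2ccccc2)c1=O` gives 14.6% in this assay. Compound 3 `O=C(NN1CCOCC1)c1c(O)c2cccnc2n(-c2ccccc2)c1=O` gives -26.2% in this assay, the lowest of the three numbers; its nearest neighbour is compound 2, and both steps to it lie beyond the scatter: a number 41.7 percentage points lower from compound 1 to compound 3 (beyond the scatter) and a number 40.8 percentage points lower from compound 2 to compound 3 (beyond the scatter). Between compound 1 and compound 2 the difference is small, a number 0.9 percentage points lower from compound 1 to compound 2 (within the scatter).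

Compound 4 `O=C(Nc1ccc(Cl)cc1)c1c(O)c2cccnc2n(-c2ccccc2)c1=O` is not yet measured. It differs from compound 3 by 4-chlorophenyl in place of morpholin-4-yl on an amide-type nitrogen. The step that bears most directly on this change is the one in which morpholin-4-yl replaced pyridin-2-yl on the same amide-type nitrogen, a number 40.8 percentage points lower from compound 2 to compound 3 (beyond the scatter), a large drop; compound 4 reverses that replacement toward an aromatic ring, though a carbon-only one with a chlorine rather than pyridin-2-yl. The step of a number 41.7 percentage points lower from compound 1 to compound 3 (beyond the scatter) points the same way.

Compound 4 is therefore expected to rise back to the level of compound 1 and compound 2, an estimated step of a number 41.2 percentage points higher from compound 3 to compound 4 (beyond the scatter). Compound 4 is estimated at 15% in this assay, within a range from 0% to 32%.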

Compound 4, a percentage reported as inhibition, in the whole organism at one dose (the size of the read-out at that dose, not a potency): 2.5%
For compound 4 the middle estimate is 12.5 percentage points above the measured one; the range from low to high includes it.
By their numbers in this assay, from the lowest: compound 3; then compound 4; then compounds 2 and 1 (each within the scatter of the next).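

On the amide-type nitrogen, 4-chlorophenyl recovers only part of the loss seen with morpholin-4-yl in this assay: the result is a number 28.7 percentage points higher from compound 3 to compound 4 (beyond the scatter) and still a number 12.1 percentage points lower from compound 2 to compound 4 (beyond the scatter) when set against pyridin-2-yl. Against ethoxy on the carbonyl carbon, the (4-chlorophenyl)amino group gives a number 13 percentage points lower from compound 1 to compound 4 (beyond the scatter) and so shows that an aromatic ring on this nitrogen does not by itself restore the level shared by compound 1 and compound 2, leaving compound 4 at an intermediate level above compound 3 and below that pair. No measurement is available that accounts for these differences.

Still open, from the compounds shown here alone, is whether the gap between 4-chlorophenyl and pyridin-2-yl belongs to the chlorine or to the carbon-only ring, a question that plain phenyl on the same amide-type nitrogen would address. Also open, going by these compounds, is how much of the low number of compound 3 goes with the ring oxygen of morpholin-4-yl, which piperidin-1-yl on that nitrogen would help to separate from the rest of the ring.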